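Removing a Core Hydroxy Group: Expected Effect on Jurkat Potency

The compounds below may be only part of what the source reports. "The series", "measured", "known", "first", "only" and "open" are said of these compounds alone.

Measured compounds:
- compound 1, `COc1cc2c(cc1OC)C(=O)/C(=C/c1cccc(C)c1)C2`: 1800 nM
- compound 2, `COc1cc2c(cc1OC)C(=O)/C(=C/c1ccc(O)c(C)c1)C2`: 1160 nM
- compound 3, `COc1cc2c(cc1O)C/C(=C\c1cc(C)c(O)c(C)c1)C2=O`: 530 nM

These three compounds were compared in a functional assay on Jurkat cells (Homo sapiens) for antiproliferative activity, read by MTT assay; on this read-out lower numbers stand for stronger inhibition and higher numbers for weaker inhibition. Compound 2 and compound 1 differ in one place, (hydrogen in place of hydroxy on an aromatic carbon), and this gave a 1.6-fold higher number from compound 2 to compound 1 (0.19 log units; within the scatter). Compound 3 shares its atoms with compound 2 but has them joined differently; the difference between the two cores is not broken down here. Compound 3 gives the lowest of the three numbers, and its separation from compound 2 and from compound 1 lies beyond the scatter.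

Compound 4, `COc1ccc2c(c1)C(=O)/C(=C/c1cc(C)c(O)c(C)c1)C2`, has not yet been measured. It differs from compound 3 by hydrogen in place of hydroxy on an aromatic carbon. For the measured compounds named here, this is the same kind of change as the one from compound 2 to compound 1, but not the same: there the hydroxy left a position ortho to a methyl group and para to a large group, whereas here it leaves a carbon of the fused two-ring system, ortho to a methoxy group. In this assay, the earlier step, a 1.6-fold higher number from compound 2 to compound 1 (0.19 log units; within the scatter), stayed within the scatter, so the step from compound 3 to compound 4 is expected to be modest as well, estimated at a 1.6-fold higher number from compound 3 to compound 4 (0.21 log units; within the scatter). That expectation rests on compound 3 at 530 nM and on the size of the step of a 1.6-fold higher number from compound 2 to compound 1 (0.19 log units; within the scatter). Compound 4 is therefore expected to give about 850 nM in this assay, with a range of 350 nM to 2100 nM.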

Compound 4, half-maximal inhibitory concentration: > 50000 nM
Compound 4 was reported as a limit; the forecaster's own chance of this, stated with the estimate: 5%; at least 58-fold (1.76 log units) between middle value and limit.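

In this assay, putting hydrogen in place of the hydroxy on the fused two-ring system gave an at least 94-fold higher number from compound 3 to compound 4 (1.97 log units; beyond the scatter), so this step is large, while the same kind of change on the core of compound 2 stayed within the scatter. The size of this change therefore did not carry from one core to the other, and the two steps really do differ: the same change on two cores in this assay, a 1.6-fold higher number (0.19 log units; within the scatter) from compound 2 to compound 1 and an at least 94-fold higher number (1.97 log units; beyond the scatter) from compound 3 to compound 4, at least 60-fold (1.78 log units) apart, beyond the scatter of two such steps

Compound 4 gives > 50000 nM, which is a limit of the assay and not a number, so the step has a lower bound but no known size, and two steps alone cannot show why the change behaves so differently on the two cores or what it would do on a third: the limit of > 50000 nM in this assay, at which 1 of the 4 values shown sits.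

The compounds shown leave open whether the carbon ortho to a methoxy group needs a hydroxy specifically, or whether another group there, such as an amine or a carboxylic acid, could keep the number close to that of compound 3 at 530 nM. They also leave open what removing the other hydroxy, on the ring that carries the methyl groups, would do on the core of compound 3.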